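Swapping fluoro for nitro at the assay limit

A few compounds are considered here, and "the series" means these few. Any claim that something is new, unique, unknown or untested is made for them only; others in the source may bear on it.

Measured in a functional assay on Jurkat cells (Homo sapiens) for antiproliferative activity, read by MTT assay, with a stated time of 72 h; a lower number here means a stronger inhibitor, a higher number a weaker inhibitor:
- compound 1 `COc1cc(-c2ncnn2-c2cccc(F)c2)cc(OC)c1OC`: > 10000 nM
- compound 2 `COc1cc(-c2ncnn2-c2cccc(N)c2)cc(OC)c1OC`: > 10000 nM
- compound 3 `COc1cc(-c2ncnn2-c2ccc(F)cc2)cc(OC)c1OC`: > 10000 nM

Each of these entries is a limit, not a number. Going by these compounds, compound 3 gives > 10000 nM, which is only a limit, so its true strength stays unknown. It shares this position with the other two compounds: the limit of > 10000 nM in this assay, at which 3 of the 3 values shown sit.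

Compound 4 `COc1cc(-c2ncnn2-c2ccc([N+](=O)[O-])cc2)cc(OC)c1OC` has nitro in place of fluoro on an aromatic carbon, para to a large group: nitro in place of fluoro on an aromatic carbon. The closest measured change is another exchange on an aromatic carbon, a step that the two limits leave unreadable from compound 1 to compound 2. The other two measured changes concern the aromatic group itself: a step that the two limits leave unreadable from compound 1 to compound 3, and a step that the two limits leave unreadable from compound 2 to compound 3. None of these steps has a size that can carry over to the new change, so no direction can be named. In this assay, no step beyond the scatter is expected, and the most likely result is another limit.

Compound 4 is estimated at 15000 nM. Its expected range runs from 5000 nM to 40000 nM. The expected change is a step that the limit leaves unreadable from compound 3 to compound 4.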

Compound 4, half-maximal inhibitory concentration: > 10000 nM
Compound 4: only a limit was reported; the forecaster's own chance of this, stated with the estimate: 80%; the middle value does not contradict the limit.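

Compound 4 gives > 10000 nM, which is a limit and not a number, so no size can be read for the change from compound 3 to compound 4. The compounds shown leave open whether nitro or fluoro gives the stronger inhibitor, and how strong any of them truly is.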